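A few compounds are considered here, and "the series" means these few. Any claim that something is new, unique, unknown or untested is made for them only; others in the source may bear on it.

Within the data shown here, in a functional assay on COR-L23 cells (Homo sapiens) for antiproliferative activity, read by CellTiter-Glo, with a stated time of 4 days (a lower number here means a stronger inhibitor, a higher number a weaker inhibitor), compound 1 (`C[C@H](NC(=O)CC(F)(F)F)c1ccc(NC(=O)[C@H]2C[C@@H]2c2cccnc2)cc1`) gives 18 nM, and compound 2 (`COCC(=O)N[C@@H](C)c1ccc(NC(=O)[C@H]2C[C@@H]2c2cccnc2)cc1`) gives 111 nM, the higher of the two numbers so far. Among the measured compounds shown here, the only measured step, a 6.2-fold higher number from compound 1 to compound 2 (0.79 log units; beyond the scatter), puts methoxy in place of trifluoromethyl on a saturated chain carbon bound to a carbonyl carbon, and it lies beyond the scatter. Compound 3 (`C[C@H](NC(=O)[C@@H]1CCCN1C)c1ccc(NC(=O)[C@H]2C[C@@H]2c2cccnc2)cc1`) has not yet been measured. It keeps the core of compound 2 and carries 1-methylpyrrolidin-2-yl in place of methoxymethyl on a carbonyl carbon. The measured step bears on this change only in part. It shows that a modest shift can follow an exchange in the group on that carbonyl carbon, but it involves no ring. For the measured compounds named here, the data hold no example of a ring entering there, so no direction is firmly expected, and the expectation in this assay is a step within the scatter, with a wide margin either way. The expected step is a 1.4-fold lower number from compound 2 to compound 3 (0.14 log units; within the scatter). For compound 3 the estimated value is 80 nM, with an expected range from 20 nM to 320 nM.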

Compound 3, half-maximal inhibitory concentration: 11 nM
Beside the measured number, compound 3's estimate is 7.3-fold (0.86 log units) above it; the whole stated range lies above it.
By their numbers in this assay, from the lowest: compounds 3 and 1 (each within the scatter of the next); then compound 2.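

In this assay, among these compounds, the place on the carbonyl carbon proves able to carry a ring, which the earlier compounds could not show: with 1-methylpyrrolidin-2-yl there, the series records a 10-fold lower number from compound 2 to compound 3 (1.00 log units; beyond the scatter). The new group also brings the number level with that of the trifluoroethyl amide, with a 1.6-fold lower number from compound 1 to compound 3 (0.21 log units; within the scatter), so 2,2,2-trifluoroethyl and 1-methylpyrrolidin-2-yl cannot be told apart here despite sharing neither ring nor nitrogen, while methoxymethyl stands apart from both. No measurement at hand gives a cause for either step.

With only one ring-bearing group shown, the compounds leave open whether the ring, its nitrogen or its defined stereocentre accounts for the step from methoxymethyl. It remains to be seen whether the opposite configuration at that stereocentre, the same ring without its methyl, a six-membered piperidine ring or an open-chain amine such as dimethylaminomethyl would hold the number at this level.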